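The source may hold more compounds than are shown below. What is called first, only, known or untested is meant among the compounds shown, and "the series" means these compounds.

Of the compounds shown here, three in this set have been measured in an assay on cells (Hepatocyte) for inhibition of glucokinase regulatory protein (Mus musculus), with stated times of 20 min and 40 min; a higher number here means that more compound is needed for the effect, a lower number that less compound is needed. Compound 1 `CC#C[C@H]1CN(S(=O)(=O)c2ccc(N)nc2)CCN1c1ccc(S(=O)(=NC)C(F)(F)F)cc1` gives 2060 nM. Compound 2 `C#CCC(O)(c1ccc(N2CCN(S(=O)(=O)c3ccc(N)nc3)C[C@@H]2C#CC)cc1)C(F)(F)F` gives 130 nM, and compound 3 `CC#CCC(O)(c1ccc(N2CCN(S(=O)(=O)c3ccc(N)nc3)C[C@@H]2C#CC)cc1)C(F)(F)F` gives 137 nM. Compound 3 thus stands second of the three numbers, close to compound 2 and far from compound 1: the step of a 1.1-fold higher number from compound 2 to compound 3 (0.02 log units; within the scatter) lies within the scatter, while the steps of a 16-fold lower number from compound 1 to compound 2 (1.20 log units; beyond the scatter) and a 15-fold lower number from compound 1 to compound 3 (1.18 log units; beyond the scatter) are both large.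

Compound 4 `CC#C[C@H]1CN(S(=O)(=O)c2ccc(N)nc2)CCN1c1ccc(C(C)=O)cc1` has not yet been measured. It differs from compound 3 in one place: a group of 3 heavy atoms (2 carbon, 1 oxygen; no ring) in place of a group of 10 heavy atoms (6 carbon, 1 oxygen, 3 fluorine; no ring), on an aromatic carbon. In words, the acetyl, with its single hydrogen-bond acceptor and no donor, replaces the larger group that carried one hydrogen-bond donor, one acceptor and a triple bond, on the six-membered aromatic ring of carbon only, para to a large group.

Among the compounds with values here, no measured step covers this exchange directly. The steps bearing on it are those from compound 1 to compounds 2 and 3, which show that swapping the whole group at this position can move the number a great deal, while the step from compound 2 to compound 3 shows that a small change at the end of the chain hardly matters. Since the acetyl removes most of the group, a sizable rise in the number is expected rather than a small one. The expected step is an 11-fold higher number from compound 3 to compound 4 (1.04 log units; beyond the scatter). Compound 4 is therefore estimated at 1500 nM, with a likely range from 300 nM to 7000 nM.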

Compound 4, half-maximal effective concentration: > 12500 nM
Compound 4 gave a limit, no number (the forecaster's own chance of this, stated with the estimate: 10%); middle value at least 8.3-fold (0.92 log units) away from the limit.
By their numbers in this assay, from the lowest: compounds 2 and 3 (each within the scatter of the next); then compound 1. At a limit, above all of these: compound 4.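

In this assay, compound 4 gives only a limit of the assay, not a number: the limit of > 12500 nM in this assay, at which 1 of the 4 values shown sits.

Cutting the group on this aromatic carbon down to acetyl costs far more than the change at the end of the chain did, with a large step of an at least 91-fold higher number from compound 3 to compound 4 (1.96 log units; beyond the scatter) and a similarly large one of an at least 96-fold higher number from compound 2 to compound 4 (1.98 log units; beyond the scatter). Compound 1, which has a quite different group at this position, also separates from the acetyl, with an at least 6.0-fold higher number from compound 1 to compound 4 (0.78 log units; beyond the scatter), so all three groups that give a number here hold three fluorine atoms and more heavy atoms than the acetyl, which has no fluorine.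

As far as these compounds go, what remains open is which part of the larger group matters, as the exchange from compound 3 to compound 4 removes the hydroxyl, the trifluoromethyl and the triple bond in a single change. A trifluoroacetyl group, or a simple tertiary alcohol without fluorine, at the same aromatic carbon would begin to separate these parts, and a longer chain ending in a triple bond would test how far the chain can extend.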